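Benzylsulfonyl in place of cyanophenylsulfonyl on an inactive scaffold

The compounds below may be only part of what the source reports. "The series", "measured", "known", "first", "only" and "open" are said of these compounds alone.

Compound 1, `COC(=O)c1cc(=O)c2c(OC)cc(OC)cc2n1C`: in a functional assay on KOPN-8 cells (Homo sapiens) for antiproliferative activity, with a stated time of 72 h (on this read-out lower numbers stand for an effect already at smaller amounts and higher numbers for an effect only at larger amounts of compound), compound 1 gives > 19000 nM, a limit of the assay rather than a number.
Compound 2, `COc1ccc(-c2cc(=O)c3c(OC)cc(OC)cc3n2S(=O)(=O)c2ccc(C#N)cc2)cc1`: compound 2 gives > 17200 nM, likewise a limit.

Both measured values are limits (the limit of > 17200 nM in this assay, at which 1 of the 2 values shown sits, (the limit of > 19000 nM in this assay, at which 1 of the 2 values shown sits)), so compound 2 stands at the edge of what this assay reports, with no number to rank it. Compound 3, `COc1ccc(-c2cc(=O)c3c(OC)cc(OC)cc3n2S(=O)(=O)Cc2ccccc2)cc1`, differs from compound 2 by benzyl in place of 4-cyanophenyl on a sulfonyl sulfur. Going by the values given here, no measured step is available to size this change. With compound 2 at a limit, the expected step that the limit leaves unreadable from compound 2 to compound 3 is none beyond the scatter. Compound 3 is estimated at 20000 nM, within 5000 nM to 60000 nM, most likely reported again as a limit.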

Compound 3, half-maximal effective concentration: > 34400 nM
Compound 3: only a limit was reported; the forecaster's own chance of this, stated with the estimate: 80%; middle value at least 1.7-fold (0.23 log units) from the limit.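

Going by these compounds alone, compound 2 and compound 3 are both reported only as limits, and no step between them can be read. The compounds shown leave open whether benzyl in place of 4-cyanophenyl changes the antiproliferative effect at all.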